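Thiazole to thiophene on the shared core: solubility notes

This account rests on a few compounds, and the source may have more. Where it says the series, first, only, none or still open, it means among the compounds named here.

Compound 1 `CSc1nc(C(C)(C)C)nc2nc(N)c(C#N)c(N)c12`: 14000 nM
Compound 2 `CCCCc1nc(C(C)(C)C)nc2nc(N)c(C#N)c(N)c12`: 6000 nM
Compound 3 `CC(C)(C)c1nc(-c2nccs2)c2c(N)c(C#N)c(N)nc2n1`: < 1500 nM
Compound 4 `CC(C)(C)c1nc(-c2ccsc2)c2c(N)c(C#N)c(N)nc2n1`: not yet measured

In a physicochemical assay for solubility, in phosphate buffer, with a stated time of 18 h (on this read-out lower numbers stand for lower solubility and higher numbers for higher solubility), compound 3 gives < 1500 nM, which is a limit of the assay and not a number. The other two compounds lie clearly higher, with an at least 9.3-fold lower number from compound 1 to compound 3 (0.97 log units; beyond the scatter) and an at least 4.0-fold lower number from compound 2 to compound 3 (0.60 log units; beyond the scatter), both beyond the scatter. Between those two, the measured change is a 2.3-fold lower number from compound 1 to compound 2 (0.37 log units; beyond the scatter).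

Compound 4 carries thiophen-3-yl in place of 1,3-thiazol-2-yl on the same aromatic carbon (thiophen-3-yl in place of 1,3-thiazol-2-yl on an aromatic carbon). The two steps to compound 3 bear on this change only indirectly, since each starts from an open-chain group and neither compares two five-membered aromatic rings. With one such ring leaving and another entering, no step beyond the scatter is expected in this assay, in either direction, and compound 4 may also return only a limit. The expected change is a step that the limit leaves unreadable from compound 3 to compound 4. For compound 4 the estimate is 1100 nM, with an expected range from 500 nM to 3000 nM.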

Compound 4, solubility: 40000 nM
Beside the measured number, compound 4's estimate is 36-fold (1.56 log units) below it, and the stated range ends below it.
By their numbers in this assay, from the lowest: compound 2; then compound 1; then compound 4. At a limit, below all of these: compound 3.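

In this assay, exchanging one five-membered aromatic ring for another on this aromatic carbon gives an at least 26-fold higher number from compound 3 to compound 4 (1.42 log units; beyond the scatter), so the identity of the ring matters here and not merely the presence of one. Compound 3 sits at a limit and not a number, so this step has a lower bound only: the limit of < 1500 nM in this assay, at which 1 of the 4 values shown sits A ring at this position also does not go with the lowest number as such, since thiophen-3-yl ends above both open-chain groups, with a 6.7-fold higher number from compound 2 to compound 4 (0.82 log units; beyond the scatter) and a 2.9-fold higher number from compound 1 to compound 4 (0.46 log units; beyond the scatter).

The step changes both the count of hetero atoms in the ring and its point of attachment, and the compounds shown do not separate the two. Going by these compounds, how thiophen-2-yl, phenyl or an amine on this aromatic carbon would read remains open.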